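The source may hold more compounds than are shown below. What is called first, only, known or untested is meant among the compounds shown, and "the series" means these compounds.

Measured compounds in an ADME assay on microsomes from liver (Mus musculus) for metabolic stability, read by LC-MS, using NADPH, with stated times of 15 min and 60 min, tested at 4.6 uM; on this read-out higher numbers stand for a longer-lived compound and lower numbers for a shorter-lived compound:

compound 1 `CN1CCC(c2ccc3c(c2)oc(=O)n3C(=O)NCCOCc2ccccc2)CC1` — 0.5 h
compound 2 `CN1CCC(c2ccc3c(c2)oc(=O)n3C(=O)NCCCCc2ccccc2)CC1=O` — 0.583 h
compound 3 `CN1CCC(c2cc3oc(=O)n(C(=O)NCCCCc4ccccc4)c3cc2F)CC1` — > 1 h

In this assay compound 2 gives 0.583 h and compound 1 gives 0.5 h; these two values sit within the usual scatter of each other, so no order between them can be read. For the measured compounds named here, compound 3 reaches only a limit of the assay, (the limit of > 1 h in this assay, at which 1 of the 3 values shown sits), and not a number; it is the one value in the set that cannot be placed against the others.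

Compound 4 `CN1CCN(c2ccc3c(c2)oc(=O)n3C(=O)NCCCCc2ccccc2)C(=O)C1` is not yet measured. It differs from compound 2 in one place: 4-methyl-2-oxopiperazin-1-yl in place of 1-methyl-2-oxopiperidin-4-yl on an aromatic carbon. Going by the values given here, no step between measured compounds mirrors this exchange, so the size of the step in this assay cannot be drawn from the set; the expectation is that the step lies within the scatter, with no clear direction. On that basis compound 4 is estimated at 0.6 h in this assay, with a range from 0.3 h to 1.2 h, which corresponds to an expected step of a 1.0-fold higher number from compound 2 to compound 4 (0.01 log units; within the scatter).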

Compound 4, half-life: < 0.0834 h
Compound 4: no number, only a limit; the forecaster's own chance of this, stated with the estimate: 20%; middle value at least 7.1-fold (0.85 log units) away from the limit.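

In this assay, the exchange of 1-methyl-2-oxopiperidin-4-yl for 4-methyl-2-oxopiperazin-1-yl on an aromatic carbon gives an at least 6.9-fold lower number from compound 2 to compound 4 (0.84 log units; beyond the scatter), so this place responds strongly to the make-up of the ring, although both groups are six-membered non-aromatic rings with no net charge. For the compounds shown here, the earlier compounds offered no step between compounds differing in one place, so this is the only step read at this position. The result for compound 4 is a limit and not a number, so the step has a minimum size only: the limit of < 0.0834 h in this assay, at which 1 of the 4 values shown sits.

The compounds shown do not separate the effect of the ring nitrogen on the aromatic carbon from that of the methyl-bearing ring nitrogen. A morpholin-4-yl group at the same place would test whether the shorter-lived read-out persists without the methyl-bearing nitrogen.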